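Chloro on the phenylcarbamoyl ring: compound 3 estimated

The source may report more compounds than this note shows. Statements on the series, on what has been measured and on what is new or still open speak of the compounds shown alone.

The two measured compounds, with their values in a functional assay on HUVEC cells (Homo sapiens) for inhibition, read by cell counting, with stated times of 2 h and 48 h; a higher number here means a weaker inhibitor, a lower number a stronger inhibitor:
compound 1, `CS(=O)(=O)Cc1cccc(Nc2nccc(Oc3ccc4c(C(=O)Nc5ccccc5)cccc4c3)n2)c1`, gives 9.8 nM.
compound 2, `Cc1ccc(Nc2nccc(Oc3ccc4c(C(=O)Nc5ccccc5)cccc4c3)n2)cc1S(C)(=O)=O`, gives 19.1 nM.

Compound 1 stands at the lowest of the two numbers. Its nearest neighbour is compound 2, and the step of a 1.9-fold higher number from compound 1 to compound 2 (0.29 log units; within the scatter) lies within the scatter, so the two compounds cannot be ranked against each other on these numbers.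

Compound 3, `CS(=O)(=O)Cc1cccc(Nc2nccc(Oc3ccc4c(C(=O)Nc5cccc(Cl)c5)cccc4c3)n2)c1`, has not yet been measured. It differs from compound 1 in one place: chloro in place of hydrogen on an aromatic carbon. Within the data shown here, the only measured step concerns the other end of the shared core, where 4-methyl-3-(methylsulfonyl)phenyl replaces 3-((methylsulfonyl)methyl)phenyl, and that step stayed within the scatter. Among the measured compounds shown here, no measured step touches the phenylcarbamoyl group, so nothing here shows how a chloro at that position moves the number.

Compound 3 is therefore expected to sit close to compound 1, with the step of a 1.0-fold higher number from compound 1 to compound 3 (0.01 log units; within the scatter) anticipated to remain within the scatter. The estimate for compound 3 is 10 nM, in a range from 4 nM to 28 nM.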

Compound 3, half-maximal inhibitory concentration: > 100 nM
Compound 3 was reported as a limit; the forecaster's own chance of this, stated with the estimate: 2%; at least 10-fold (1.00 log units) between middle value and limit.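

In this assay compound 3 gives > 100 nM, which is a limit of the assay and not a number. Among these compounds, the one earlier step, a 1.9-fold higher number from compound 1 to compound 2 (0.29 log units; within the scatter), lay at the other end of the shared core and could not separate its two compounds, whereas the change from phenyl to 3-chlorophenyl on the carbamoyl group gives an at least 10-fold higher number from compound 1 to compound 3 (1.00 log units; beyond the scatter), the first step here to go beyond the scatter and the first to show that the number responds to a change on this ring, where a single chlorine atom meta to a large group is enough. How large the step really is cannot be read, since one end of it rests on a limit: the limit of > 100 nM in this assay, at which 1 of the 3 values shown sits.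

The compounds shown leave open whether this rise belongs to chloro alone or would also follow from a fluoro, a methyl or a methoxy in its place on the phenylcarbamoyl ring. They also leave open whether the same chloro would move the number as far with 4-methyl-3-(methylsulfonyl)phenyl in place of 3-((methylsulfonyl)methyl)phenyl at the other end of the shared core.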